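This account rests on a few compounds, and the source may have more. Where it says the series, first, only, none or still open, it means among the compounds named here.

Measured so far in a functional assay on MDA-MB-468 cells (Homo sapiens) for cytotoxicity, read by resazurin assay, with a stated time of 72 h; on this read-out higher numbers stand for weaker inhibition and lower numbers for stronger inhibition: compound 1 `N#CCCSC(=S)NCc1cccnc1` gives 9530 nM; compound 2 `CC(=O)CCSC(=S)NCc1cccnc1` gives 4220 nM.

Compound 2 stands at the lowest number of the two, with a 2.3-fold lower number from compound 1 to compound 2 (0.35 log units; beyond the scatter). Compound 3 `OCCCSC(=S)NCc1cccnc1` differs from compound 2 by hydroxymethyl in place of acetyl on a saturated chain carbon, two bonds along the chain from a sulfur. Going by the values given here, the one known step touches the same chain position but exchanges a different group, so it bears on compound 3 only loosely; no step from acetyl to hydroxymethyl has been measured. For compound 3 the expected step in this assay is a 1.5-fold higher number from compound 2 to compound 3 (0.19 log units; within the scatter), with an estimate of 6500 nM and a range of 2500 nM to 17000 nM.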

Compound 3, half-maximal inhibitory concentration: 6610 nM
Estimate against measurement, compound 3: 1.0-fold (0.01 log units) below, and the stated range covers the measured number.
By their numbers in this assay, from the lowest: compounds 2, 3 and 1 (each within the scatter of the next, the first and the last beyond it).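

In this assay, hydroxymethyl on a saturated chain carbon, two bonds along the chain from a sulfur, brings in a hydrogen-bond donor, yet neither new step leaves the scatter (a 1.6-fold higher number from compound 2 to compound 3 (0.19 log units; within the scatter); a 1.4-fold lower number from compound 1 to compound 3 (0.16 log units; within the scatter)). Compound 3 therefore cannot be ordered against compound 1 or compound 2, and only the exchange of cyano for acetyl remains beyond the scatter at this position. No measured evidence bears on why these numbers lie so close.

From the compounds shown here alone, whether an amine or a carboxylic acid at this carbon would move the number further stays open. So does the effect of a longer chain.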